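The source may report more compounds than this note shows. Statements on the series, on what has been measured and on what is new or still open speak of the compounds shown alone.

Compound 1 `ClCc1ccc(Cn2cnc3nc(Cl)nc(Cl)c32)cc1`: 64600 nM
Compound 2 `Nc1nc(Cl)c2ncn(Cc3cccc(CCl)c3)c2n1`: 57500 nM

In a functional assay on SW-620 cells (Homo sapiens) for cytotoxicity, read by sulforhodamine B assay, with a stated time of 48 h (on this read-out lower numbers stand for higher toxicity in this test and higher numbers for lower toxicity in this test), compound 1 gives 64600 nM and compound 2 gives 57500 nM. On these two numbers compound 1 holds the higher one, but the gap to compound 2 lies within the scatter of repeated measurements and so does not set the two apart.

Compound 3 `ClCc1ccc(Cn2cnc3ncnc(Cl)c32)cc1` has not been measured in this assay. It differs from compound 1 in one place: hydrogen in place of chloro on an aromatic carbon. For the measured compounds named here, no measured pair with a comparable change is available, so the size of the step from compound 1 to compound 3 cannot be read from the data. Given the closely similar values of compound 1 and compound 2, a step of a 1.2-fold higher number from compound 1 to compound 3 (0.09 log units; within the scatter) is expected, which is small and within the scatter. Compound 3 is therefore estimated at 80000 nM, with a range from 30000 nM to 200000 nM.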

Compound 3, concentration lethal to 50% of the cells: 32400 nM
Estimate against measurement, compound 3: 2.5-fold (0.39 log units) above; the measured number falls inside the stated range.
By their numbers in this assay, from the lowest: compounds 3, 2 and 1 (each within the scatter of the next).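

Hydrogen in place of chloro on an aromatic carbon, between two ring nitrogen atoms, gives a 2.0-fold lower number from compound 1 to compound 3 (0.30 log units; within the scatter) in this assay. For the compounds shown here, this is the first step read at this place, and it shows that exchanging this chloro for hydrogen leaves compound 3 within the scatter of compound 1, so the two are not set apart in this test. Nothing further measured on these compounds bears on this result.

What the compounds shown leave open is whether a methoxy group or a methyl group at this same place would give a step beyond the scatter. Also open, from the compounds shown here alone, is whether the remaining chloro group on the six-membered ring, or the chloromethyl group on the benzyl ring, could give way to hydrogen with as small a step.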